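This account rests on a few compounds, and the source may have more. Where it says the series, first, only, none or still open, it means among the compounds named here.

In an ADME assay on L929 cells (Mus musculus) for cytotoxicity, read by resazurin assay, with a stated time of 72 h (on this read-out higher numbers stand for weaker inhibition and lower numbers for stronger inhibition), compound 1 `CCc1ccc(C(=O)c2ccn(-c3ccc4c(c3)B(O)OC4)c2)cc1` gives > 10 ug/mL, which is a limit of the assay and not a number. Compound 2 `NCc1ccc(C(=O)c2ccn(-c3ccc4c(c3)B(O)OC4)c2)cc1` gives > 10 ug/mL, again a limit. Compound 3 `O=C(c1ccn(-c2ccc3c(c2)B(O)OC3)c1)C1CCCCC1` gives > 10 ug/mL, also a limit. Compound 3 therefore stands where the other two stand, since all three values sit at the limit of > 10 ug/mL in this assay, at which 3 of the 3 values shown sit. The measured steps are a step that the two limits leave unreadable from compound 1 to compound 2, a step that the two limits leave unreadable from compound 1 to compound 3 and a step that the two limits leave unreadable from compound 2 to compound 3, and none of them can be read in size. Compound 4 `O=C(c1ccn(-c2ccc3c(c2)B(O)OC3)c1)c1cccs1` differs from compound 3 by thiophen-2-yl in place of cyclohexyl on a carbonyl carbon. For the measured compounds named here, no measured step touches this change, and the three measured steps give no size because every value shown is a limit at the limit of > 10 ug/mL in this assay, at which 3 of the 3 values shown sit. The step that the limit leaves unreadable from compound 3 to compound 4 in this assay is expected to be no more than what a further limit would show. Compound 4 is estimated to give 15 ug/mL, with a range from 5 ug/mL to 50 ug/mL, and is expected most likely to be reported as a limit once more.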

Compound 4, half-maximal inhibitory concentration: > 10 ug/mL
Compound 4 was reported as a limit; the forecaster's own chance of this, stated with the estimate: 85%; the middle value does not contradict the limit.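

In this assay compound 4 gives > 10 ug/mL, which is a limit and not a number. Its steps to compound 1, compound 2 and compound 3 cannot be read in size. The compounds shown leave open whether they differ at all in cytotoxicity, as all sit at one limit: the limit of > 10 ug/mL in this assay, at which 4 of the 4 values shown sit.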